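A few compounds are considered here, and "the series" means these few. Any claim that something is new, unique, unknown or untested is made for them only; others in the source may bear on it.

Of the compounds shown here, three built on a shared core have been tested in a functional assay on A-431 cells (Homo sapiens) for cytotoxicity, read by MTT assay, with a stated time of 72 h, tested at 100 uM; a lower number here means less inhibition of growth, a higher number more inhibition of growth at the concentration tested. Compound 1 `Cc1ccnc(/C(N)=N/NC(=S)N2CCN(c3ccccn3)CC2)c1` gives 75.5%. Compound 3 `Cc1cccc(/C(N)=N/NC(=S)N2CCCCC2)n1` gives 77.5%, and compound 2 `N/C(=N\NC(=S)N1CCCCC1)c1ccccn1` gives 85.6%. Compound 3 and compound 2 differ in one place, (hydrogen in place of methyl on an aromatic carbon), and this gave a number 8.1 percentage points higher from compound 3 to compound 2 (within the scatter).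

Compound 4 `N/C(=N\NC(=S)N1CCN(c2ccccn2)CC1)c1ccccn1` is still to be measured in this assay. It differs from compound 1 by the same kind of change, (hydrogen in place of methyl on an aromatic carbon). The surroundings of the place are not identical: in compound 1 the methyl sits meta to a large group and opposite the ring nitrogen, whereas in compound 3 it sits next to the ring nitrogen and meta to a large group. The difference between the cores of compound 1 and compound 3 is not broken down here.

Because a number 8.1 percentage points higher from compound 3 to compound 2 (within the scatter) stayed within the scatter, only a small step is expected for compound 4, namely a number 4.5 percentage points higher from compound 1 to compound 4 (within the scatter). Compound 4 is therefore estimated to give 80% in this assay, most likely between 68% and 92%.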

Compound 4, percent growth inhibition at one concentration: 91.9%
For compound 4 the middle estimate is 11.9 percentage points below the measured one; measured number inside the range.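

In this assay, putting hydrogen in place of the methyl, the change from 4-methylpyridin-2-yl to pyridin-2-yl, gives a number 16.4 percentage points higher from compound 1 to compound 4 (beyond the scatter). Set beside the earlier pair, the change points the same way on both cores, and the two steps cannot be told apart in size: the same change on two cores in this assay, a number 8.1 percentage points higher (within the scatter) from compound 3 to compound 2 and a number 16.4 percentage points higher (beyond the scatter) from compound 1 to compound 4, 8.3 percentage points apart, within the scatter of two such steps. This is agreement in direction across two pairs only; it is no general rule, since just one of the two steps lies beyond the scatter, the methyl sits at a different place on the ring in each pair, and the numbers do not explain why the growth inhibition differs.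

The compounds shown have only methyl or hydrogen on this ring, so it remains open how a longer chain such as ethyl, a methoxy group, a chlorine atom or an amine would behave there. Also open, as far as these compounds go, is whether the same step would appear on a core with a different group on the far side of the molecule from this ring.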